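Shortening the cyclopropylalkyl ether by one carbon

The compounds below may be only part of what the source reports. "The series", "measured", "known", "first", "only" and "open" are said of these compounds alone.

Of the compounds shown here, two sharing one core have been measured in an assay on cells with melanin-concentrating hormone receptor 1 (Homo sapiens) as the target, read by radioligand binding; a lower number here means a stronger inhibitor, a higher number a weaker inhibitor. Compound 1 `COCC(C)Oc1cccc2ccc(N)nc12` gives 606 nM in this assay. Compound 2 `Nc1ccc2cccc(OCCC3CC3)c2n1` gives 492 nM in this assay. The step of a 1.2-fold lower number from compound 1 to compound 2 (0.09 log units; within the scatter) is within the scatter, so compound 2 stands level with compound 1 rather than apart from it. Compound 3 `Nc1ccc2cccc(OCC3CC3)c2n1` differs from compound 2 by cyclopropyl in place of cyclopropylmethyl on a saturated chain carbon bound to an oxygen on an aromatic ring. Among the compounds with values here, only one measured step exists, a 1.2-fold lower number from compound 1 to compound 2 (0.09 log units; within the scatter), and it exchanges one side chain on the ring oxygen for another of similar length rather than shortening a chain; it shows that a change at this position moved the number little. Within the data shown here, no step that removes one carbon from this chain has been measured. On that basis no step beyond the scatter is expected for compound 3, the estimated step being a 1.2-fold higher number from compound 2 to compound 3 (0.09 log units; within the scatter). Compound 3 is therefore expected to give about 600 nM in this assay, within a range from 250 nM to 1500 nM.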

Compound 3, half-maximal inhibitory concentration: > 2000 nM
Compound 3: no number, only a limit; the forecaster's own chance of this, stated with the estimate: 3%; at least 3.3-fold (0.52 log units) between middle value and limit.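

In this assay, compound 3 carries only a limit of the assay and not a number: the limit of > 2000 nM in this assay, at which 1 of the 3 values shown sits.

The earlier pair showed that one side chain on the ring oxygen could replace another with no change beyond the scatter, but it did not show that this position responds to chain length. Going from 2-cyclopropylethyl to cyclopropylmethyl gives an at least 4.0-fold higher number from compound 2 to compound 3 (0.60 log units; beyond the scatter), so the shorter chain is clearly worse here. The exchange of 1-(methoxymethyl)ethyl for cyclopropylmethyl points the same way, with an at least 3.3-fold higher number from compound 1 to compound 3 (0.51 log units; beyond the scatter).

Going by these compounds, how far the true number of compound 3 lies past its limit stays open, and so does the full size of both steps. Also open, on these data alone, is whether a longer chain such as 3-cyclopropylpropyl, or an amine at the end of the chain, would bring the number down further.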